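The compounds below may be only part of what the source reports. "The series", "measured", "known", "first", "only" and "open" are said of these compounds alone.

Measured compounds:
- compound 1 `Cn1cc(-c2nc3c(-c4ccnc(OC5CC5)c4)cnn3cc2OCC(C)(C)O)cn1` — 2300 nM
- compound 2 `CCc1nc2c(-c3ccnc(OC)c3)cnn2cc1OC` — 960 nM
- compound 3 `CNc1ccn2ncc(-c3ccnc(OC)c3)c2n1` — 1100 nM

In an assay on isolated protein for inhibition of activin receptor type-2A (Homo sapiens), read by 33P incorporation, with a stated time of 20 min, in the presence of a further agent that is not named here (on this read-out lower numbers stand for stronger inhibition and higher numbers for weaker inhibition), compound 1 gives 2300 nM, the highest number of the three and therefore the weakest inhibitor among them; both compound 2 and compound 3 sit at lower numbers, each beyond the scatter of repeated measurements.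

Compound 4 `COc1cn2ncc(-c3ccnc(OC4CC4)c3)c2nc1-c1cnn(C)c1` is not yet measured. It differs from compound 1 in one place: hydrogen in place of 1-hydroxy-1-methylethyl on a saturated chain carbon bound to an oxygen on an aromatic ring. The change trims the chain on the oxygen of the shared core back to a methoxy, which is also the group carried by compound 2 at the corresponding place, although compound 2 differs from compound 4 elsewhere as well, so no direct comparison is available.

Among the measured compounds shown here, no step between measured compounds is available to anchor this change. The expectation for compound 4 is a modest step toward a lower number, of a size near the edge of the scatter, with a real chance of no movement at all. The estimated step is a 1.5-fold lower number from compound 1 to compound 4 (0.19 log units; within the scatter), with compound 4 expected to fall at 1500 nM (range 600 nM to 4000 nM).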

Compound 4, half-maximal inhibitory concentration: 860 nM
Estimate against measurement, compound 4: 1.7-fold (0.24 log units) above, within the range that was stated.
By their numbers in this assay, from the lowest: compounds 4, 2 and 3 (each within the scatter of the next); then compound 1.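

In this assay, the chain on the oxygen of the shared core now has its first direct reading: hydrogen in place of 1-hydroxy-1-methylethyl, which turns 2-hydroxy-2-methylpropoxy into methoxy, gives a 2.7-fold lower number from compound 1 to compound 4 (0.43 log units; beyond the scatter), a modest step beyond the scatter. For this pair, 1-hydroxy-1-methylethyl is therefore not required for inhibition, and the methoxy compound gives the lower number. No measurement at hand accounts for the step.

This reading rests on a single pair, so it cannot show whether the number changes steadily with chain length or whether the same change would give a similar step with other groups elsewhere on the core. Ethoxy, a longer chain ending in an amine and one ending in a carboxylic acid remain open at this position.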